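This account rests on a few compounds, and the source may have more. Where it says the series, first, only, none or still open, it means among the compounds named here.

Values in a functional assay on A549 cells (Homo sapiens) for antiproliferative activity, read by MTT assay, with a stated time of 72 h (on this read-out lower numbers stand for stronger inhibition and higher numbers for weaker inhibition), so far:

- Compound 1 `Cc1nc(C)c(/C=C/C(=O)/C=C/c2ccccc2)nc1C` gives 12300 nM
- Compound 2 `Cc1nc(C)c(/C=C/C(=O)/C=C/c2ccc(F)cc2)nc1C` gives 5900 nM
- Compound 3 `Cc1nc(C)c(/C=C/C(=O)/C=C/c2ccc(C(F)(F)F)cc2)nc1C` is still unmeasured

Of the two measured compounds, compound 2 has the lower number (5900 nM), so it is the stronger inhibitor of the pair. The next change is trifluoromethyl in place of fluoro on an aromatic carbon, with trifluoromethyl in place of fluoro on an aromatic carbon. For the measured compounds named here, only one measured step bears on this: a 2.1-fold lower number from compound 1 to compound 2 (0.32 log units; beyond the scatter), where fluoro replaced hydrogen on an aromatic carbon. Going by the values given here, that step was modest, and no measured compound yet carries trifluoromethyl, so the evidence is thin. In this assay a step of similar or smaller size is expected, probably towards a lower number, and it may stay within the scatter. The estimate means a 1.3-fold lower number from compound 2 to compound 3 (0.12 log units; within the scatter) and carries wide uncertainty. Compound 3 is expected at 4500 nM (estimated range 1800 nM to 11000 nM).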

Compound 3, half-maximal inhibitory concentration: 11700 nM
The estimate for compound 3 lay 2.6-fold (0.41 log units) below the measured number; measured number outside the range, above it.
By their numbers in this assay, from the lowest: compounds 2, 3 and 1 (each within the scatter of the next, the first and the last beyond it).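

In this assay, putting trifluoromethyl in place of fluoro at this position gives a 2.0-fold higher number from compound 2 to compound 3 (0.30 log units; within the scatter), so this change does not extend the gain seen earlier with fluoro, although the step stays within the scatter. Measured against hydrogen, trifluoromethyl gives a 1.1-fold lower number from compound 1 to compound 3 (0.02 log units; within the scatter), which leaves the two indistinguishable here, and so among these three compounds only the fluoro step, a 2.1-fold lower number from compound 1 to compound 2 (0.32 log units; beyond the scatter), separates a substituent from hydrogen, and only modestly. Nothing measured here offers an explanation for these results.

As far as these compounds go, it remains open how a methoxy group, chloro or an amine at the same position would compare with fluoro. Also open, from the compounds shown here alone, is whether a change elsewhere on the shared core would matter more than any swap at this position.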